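Swapping the pyridine arm of compound 3 for an aminothiazole

This account rests on a few compounds, and the source may have more. Where it says the series, first, only, none or still open, it means among the compounds named here.

Of the compounds shown here, three sharing one core have been measured in an assay for inhibition of Indoleamine 2,3-dioxygenase 1 (Homo sapiens), with a stated time of 1 h, tested at 10 uM; a lower number here means less inhibition, a higher number more inhibition at the concentration tested (going by the name of the read-out). Compound 3 `Brc1cc(NCc2ccncc2)c2cn[nH]c2c1` gives 54%, the highest of the three. Compound 1 `Brc1cc(NCc2ccco2)c2cn[nH]c2c1` gives 29%, and compound 2 `Brc1cc(NCc2cnc[nH]2)c2cn[nH]c2c1` gives 16%. All steps among them lie beyond the scatter: a number 25 percentage points higher from compound 1 to compound 3 (beyond the scatter), a number 38 percentage points higher from compound 2 to compound 3 (beyond the scatter), and a number 13 percentage points lower from compound 1 to compound 2 (beyond the scatter). Within this small set, the six-membered pyridin-4-yl group stands highest, the five-membered 1H-imidazol-5-yl group lowest, with furan-2-yl between them.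

Compound 4 `Nc1nc(CNc2cc(Br)cc3[nH]ncc23)cs1` is not yet measured. It differs from compound 3 in one place: 2-amino-1,3-thiazol-4-yl in place of pyridin-4-yl on a saturated chain carbon bound to a nitrogen on an aromatic ring. The nearest guides are the two steps that exchange the group at this same position against pyridin-4-yl, a number 25 percentage points higher from compound 1 to compound 3 (beyond the scatter) and a number 38 percentage points higher from compound 2 to compound 3 (beyond the scatter), both rising toward the pyridine and both beyond the scatter. Going the other way, from pyridin-4-yl to a five-membered ring with two hetero atoms and one hydrogen-bond donor, the expectation is a drop, and the estimated step is a number 29 percentage points lower from compound 3 to compound 4 (beyond the scatter). Compound 4 is accordingly expected to give 25%, with a likely range from 5% to 48%.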

Compound 4, a percentage reported as inhibition, at one concentration (the size of the read-out at that concentration, not a potency): "not active" (no number reported)
The entry for compound 4 holds no number; no gap can be computed for the estimate.
By their numbers in this assay, from the lowest: compound 2; then compound 1; then compound 3.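

In this assay, among the compounds shown here, compound 4 carries only the entry "not active", without a number, so no step from compound 3 to compound 4 can be read. No measurement at hand offers an explanation for this result. As far as these compounds go, how the 2-amino-1,3-thiazol-4-yl group truly compares in size with pyridin-4-yl, furan-2-yl or 1H-imidazol-5-yl at this place remains open.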